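The source may hold more compounds than are shown below. What is called first, only, known or untested is meant among the compounds shown, and "the series" means these compounds.

Compound 1 `CN(C)CCn1cnnc1-c1cc(Oc2ccc(NC(=O)N/N=C/c3c(Cl)cccc3Cl)cc2F)ccn1` gives > 100000 nM in a functional assay on U-87MG ATCC cells (Homo sapiens) for cytotoxicity, read by MTT assay, with a stated time of 72 h (a lower number here means a stronger inhibitor, a higher number a weaker inhibitor), which is a limit rather than a number. Compound 2 `COc1cc(/C=N/NC(=O)Nc2ccc(Oc3ccnc(-c4nncn4CCN(C)C)c3)c(F)c2)cc(OC)c1OC` gives 22500 nM in this assay.

Compound 2 thus holds the only number shown in this assay, the remaining value being a limit. The step of an at least 4.4-fold lower number from compound 1 to compound 2 (0.64 log units; beyond the scatter) is bounded by the limit of > 100000 nM in this assay, at which 1 of the 2 values shown sits. Compound 3 `CN(C)CCn1cnnc1-c1cc(Oc2ccc(NC(=O)N/N=C/c3ccc(F)cc3Cl)cc2F)ccn1` differs from compound 2 by 2-chloro-4-fluorophenyl in place of 3,4,5-trimethoxyphenyl on a carbon with a double bond to nitrogen. This change returns to a halogenated phenyl, as in compound 1, so that measured step bears on it in reverse, and a weakening beyond the scatter is expected. Compound 3 is therefore estimated at 60000 nM, between 20000 nM and 150000 nM, an expected step of a 2.7-fold higher number from compound 2 to compound 3 (0.43 log units; beyond the scatter).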

Compound 3, half-maximal inhibitory concentration: 1210 nM
Estimate against measurement, compound 3: 50-fold (1.70 log units) above; the measured number lies below the stated range.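

At the position on a carbon with a double bond to nitrogen, a halogenated phenyl is not weaker as such: in this assay, 2-chloro-4-fluorophenyl in place of 3,4,5-trimethoxyphenyl gives a 19-fold lower number from compound 2 to compound 3 (1.27 log units; beyond the scatter), reversing the order seen with the 2,6-dichlorophenyl of compound 1. The two halogenated groups also part widely, with an at least 82-fold lower number from compound 1 to compound 3 (1.91 log units; beyond the scatter). That step is bounded rather than exact: the limit of > 100000 nM in this assay, at which 1 of the 3 values shown sits.

The compounds shown leave open whether an unsubstituted phenyl, a phenyl carrying a single chlorine or a phenyl carrying an amine would follow compound 3 or compound 1. They also leave open how a carboxylic acid on the phenyl would read here.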